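Thienyl-ring aryl swap: phenyl to methylpyridinyl in a tetrazole series

This account rests on a few compounds, and the source may have more. Where it says the series, first, only, none or still open, it means among the compounds named here.

The series shares one core, carried by compound 1 `CC#C[C@@H](Cc1nnn[nH]1)c1ccc(OCc2ccc3scc(-c4ccccc4C(F)(F)F)c3c2)cc1`. In an ADME assay on microsomes from liver (Rattus norvegicus) for metabolic stability (on this read-out higher numbers stand for a longer-lived compound and lower numbers for a shorter-lived compound), compound 1 gives 0.167 h, the lowest of the two numbers recorded, while compound 3 `CC#C[C@@H](Cc1nnn[nH]1)c1ccc(OCc2ccc3sc(Cl)c(-c4ccccc4C)c3c2)cc1` gives 1.08 h in this assay, a higher number by a gap that lies beyond the scatter. Compound 2 `CC#C[C@@H](Cc1nnn[nH]1)c1ccc(OCc2cc(C)c3scc(-c4ccccc4C)c3c2)cc1` reaches only the limit of this assay, < 0.0667 h, and no number is known for it. The limit of < 0.0667 h in this assay, at which 1 of the 3 values shown sits, is the only other read-out in the set.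

Compound 4 `CC#C[C@@H](Cc1nnn[nH]1)c1ccc(OCc2ccc3scc(-c4cccnc4C)c3c2)cc1` is not yet measured. It differs from compound 1 in one place: 2-methylpyridin-3-yl in place of 2-(trifluoromethyl)phenyl on an aromatic carbon.

Among the compounds with values here, no step between measured compounds matches this change, so the expectation for this assay rests on the spread of compound 1 and compound 3 alone. The change from compound 1 to compound 4 is expected to move the half-life little, within the scatter in either direction, with a small upward lean, so the expected step of a 1.5-fold higher number from compound 1 to compound 4 (0.18 log units; within the scatter) is modest. Compound 4 is estimated at 0.25 h, within a range from 0.07 h to 0.7 h.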

Compound 4, half-life: 0.183 h
Beside the measured number, compound 4's estimate is 1.4-fold (0.14 log units) above it; low and high end bracket the measured number.
By their numbers in this assay, from the lowest: compounds 1 and 4 (each within the scatter of the next); then compound 3. At a limit, below all of these: compound 2.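

In this assay, the replacement of 2-(trifluoromethyl)phenyl by 2-methylpyridin-3-yl on the aromatic carbon two ring bonds from the ring sulfur gives a 1.1-fold higher number from compound 1 to compound 4 (0.04 log units; within the scatter). Within the data shown here, this is the first one-place step, and it shows that the half-life at this position does not separate between a carbon-only aromatic ring and an aromatic ring with one hetero atom, even though the two groups also differ in their substituent and heavy-atom count. Nothing at hand bears on why these two groups fall within the scatter of each other.

The step swaps the ring and its substituent together, so it cannot assign any share of the outcome to the ring nitrogen or to the trifluoromethyl-to-methyl exchange taken alone. On these data alone, whether a group of another kind at this position, such as a 2-methoxyphenyl or a cyclopropyl group, would lift the half-life of the core of compound 1 beyond the scatter remains open.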